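This account rests on a few compounds, and the source may have more. Where it says the series, first, only, none or still open, it means among the compounds named here.

Measured so far:
compound 1 `CN(C)C(=S)SCC1=CC(=O)OC1` gives 7550 nM
compound 2 `O=C1OCC=C1CSC(=S)N1CCOCC1` gives 26000 nM

Both compounds were tested in a functional assay on EC9706 cells (Homo sapiens) for antiproliferative activity, read by MTT assay, with a stated time of 72 h; a higher number here means a weaker inhibitor, a lower number a stronger inhibitor. Of the two numbers, compound 1 stands lowest, and the gap to compound 2 lies beyond the usual scatter of repeated measurements, so compound 1 is the stronger inhibitor of the pair. The two compounds share a core and differ only in the amine attached to the thiocarbonyl carbon: a dimethylamino group in compound 1, a morpholine ring in compound 2.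

Compound 3 `O=C1C=C(CSC(=S)N2CCCC2)CO1` has not yet been measured. It differs from compound 1 by pyrrolidin-1-yl in place of dimethylamino on a thiocarbonyl carbon. Like the morpholine of compound 2, pyrrolidin-1-yl is a ring; unlike morpholine, it carries no oxygen, and with its four carbons it sits closer in size to the dimethylamino group of compound 1. Among the measured compounds shown here, nothing among the measured compounds shows how a change of this kind moves the number, so the expected step from compound 1 to compound 3 in this assay is small, a 1.1-fold lower number from compound 1 to compound 3 (0.03 log units; within the scatter), and may well fall within the scatter. Compound 3 is therefore estimated to give 7000 nM, with a likely range from 2500 nM to 20000 nM.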

Compound 3, half-maximal inhibitory concentration: 106000 nM
Estimate against measurement, compound 3: 15-fold (1.18 log units) below; the measured number lies above the stated range.
By their numbers in this assay, from the lowest: compound 1; then compound 2; then compound 3.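

In this assay, among the compounds shown here, the group on a thiocarbonyl carbon proves far less forgiving than the earlier compounds could show: replacing dimethylamino with pyrrolidin-1-yl gives a 14-fold higher number from compound 1 to compound 3 (1.15 log units; beyond the scatter) and so turns a modest-looking swap into a large loss of antiproliferative strength. Being a ring without oxygen and closer in size to dimethylamino than morpholine did not keep the number low, since compound 3 at 106000 nM stands higher than the morpholine compound 2 at 26000 nM in this set. The data offer no measurement that accounts for this large step, so its cause remains unknown.

With only one open-chain amine and two rings, the compounds shown cannot separate the effect of closing the ring from the effect of adding carbons to the amine. A diethylamino group, which adds carbons without forming a ring, and a piperidine ring, which enlarges the ring without adding oxygen, would help to tell those two changes apart.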